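Swapping the Cyclobutyl Amine Substituent in a Bicyclic Agonist

This account rests on a few compounds, and the source may have more. Where it says the series, first, only, none or still open, it means among the compounds named here.

Measured so far:
compound 1, `CCN1CCC(NC(=O)c2nc(C(C)C)n3ccccc23)CC1`: 100%
compound 2, `CC(C)c1nc(C(=O)NC[C@@H]2[C@H]3CN(C4CCC4)C[C@@H]23)c2ccccn12`: 59%

In a functional assay on CHO cells for agonist activity at 5-hydroxytryptamine receptor 4 (Homo sapiens), read by a luciferase reporter and cAMP accumulation, with a stated time of 4 h (a lower number here means a smaller maximal response, a higher number a larger maximal response), compound 1 reaches 100%, while compound 2 reaches 59%. Compound 2 therefore stands lowest of the two numbers, and its nearest neighbour, compound 1, lies beyond the scatter above it. Among the compounds with values here, the two compounds differ in more than one place, so no single step between them is given, and only their two values can be set side by side.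

Compound 3, `COC(=O)N1CCC(N2C[C@@H]3[C@@H](CNC(=O)c4nc(C(C)C)n5ccccc45)[C@@H]3C2)CC1`, follows from compound 2 by one change: 1-(methoxycarbonyl)piperidin-4-yl in place of cyclobutyl on an amine nitrogen in a ring. Within the data shown here, no measured pair shows how such an exchange on this amine nitrogen acts in this assay. Resting only on the two values at hand, the step from compound 2 to compound 3 is expected to be modest, possibly none beyond the scatter, with no clear direction: a number 6 percentage points higher from compound 2 to compound 3 (within the scatter). For compound 3 the estimate in this assay is 65%, ranging from 40% to 90%.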

Compound 3, largest response reached (Emax), in percent of the reference or control that the assay uses: 42%
The estimate for compound 3 lay 23 percentage points above the measured number; low and high end bracket the measured number.
By their numbers in this assay, from the lowest: compound 3; then compound 2; then compound 1.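

In this assay, placing 1-(methoxycarbonyl)piperidin-4-yl instead of cyclobutyl on the amine nitrogen in a ring gives a number 17 percentage points lower from compound 2 to compound 3 (beyond the scatter). Within the data shown here, this is the first comparison in which only this substituent differs, and it shows that the group on this nitrogen can shift the maximal response, while the larger group, with its ring nitrogen and two hydrogen-bond acceptors, still leaves compound 3 with a clear response of 42%. No measurement at hand explains the decrease.

With a single exchange at this position, the compounds shown leave open whether the decrease goes with the piperidine ring or with its methoxycarbonyl group. A piperidin-4-yl group carrying a free ring amine, or a tetrahydropyran-4-yl group, would separate these two parts.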